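Removing the trifluoromethyl group from compound 3

The compounds below may be only part of what the source reports. "The series", "measured", "known", "first", "only" and "open" are said of these compounds alone.

- Compound 1 `CN(C)C(=O)c1cc2cnc(Nc3ccc(NC(=O)C4(C(=O)Nc5ccccc5F)CC4)cc3)nc2n1C1CCCC1` gives 88.6%
- Compound 2 `Cc1ccc(NC(=O)C2(C(=O)Nc3ccc(Nc4ncc5cc(C(=O)N(C)C)n(C6CCCC6)c5n4)cc3)CC2)cc1` gives 90.6%
- Compound 3 `CN(C)C(=O)c1cc2cnc(Nc3ccc(NC(=O)C4(C(=O)Nc5cccc(C(F)(F)F)c5)CC4)cc3)nc2n1C1CCCC1` gives 89.2%

These values come from a functional assay on A549 cells (Homo sapiens) for inhibition, read by CCK-8 assay, with a stated time of 72 h, tested at 10 uM; on this read-out lower numbers stand for less inhibition of growth and higher numbers for more inhibition of growth at the one concentration tested. At 89.2%, compound 3 cannot be told apart from compound 1 or compound 2. Compound 4 `CN(C)C(=O)c1cc2cnc(Nc3ccc(NC(=O)C4(C(=O)Nc5ccccc5)CC4)cc3)nc2n1C1CCCC1` differs from compound 3 by hydrogen in place of trifluoromethyl on an aromatic carbon, which means hydrogen in place of trifluoromethyl on an aromatic carbon. The closest evidence comes from exchanging the aryl group on the amide-type nitrogen, and all three steps were small: a number 2 percentage points higher from compound 1 to compound 2 (within the scatter), a number 0.6 percentage points higher from compound 1 to compound 3 (within the scatter) and a number 1.4 percentage points lower from compound 2 to compound 3 (within the scatter). Among the measured compounds shown here, no measured compound carries plain phenyl, so this is an extrapolation. In this assay, no change beyond the scatter is expected, and the expected step is a number 1.2 percentage points lower from compound 3 to compound 4 (within the scatter). Compound 4 is estimated at 88%, with an expected range of 78% to 94%.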

Compound 4, percent growth inhibition at one concentration: 88.8%
Compound 4: middle estimate off by 0.8 percentage points, on the low side, and the stated range covers the measured number.
By their numbers in this assay, from the lowest: compounds 1, 4, 3 and 2 (each within the scatter of the next).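

In this assay plain phenyl now joins the comparison, and taking away each ring substituent gives a small step: a number 0.4 percentage points lower from compound 3 to compound 4 (within the scatter) for trifluoromethyl, a number 1.8 percentage points lower from compound 2 to compound 4 (within the scatter) for methyl and a number 0.2 percentage points higher from compound 1 to compound 4 (within the scatter) for fluoro. Among these four compounds, then, the unsubstituted ring cannot be told apart from any of the three substituted rings. Nothing measured here explains this flat result.

Going by these compounds, whether an amine or a carboxylic acid on this phenyl ring would hold the number at this level remains open. Readings at a single concentration also leave open whether these compounds would separate at lower concentrations.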